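A Methylsulfanyl Group in Place of the Triazole

This account rests on a few compounds, and the source may have more. Where it says the series, first, only, none or still open, it means among the compounds named here.

Compound 1 `COc1ccc(C(=O)N2C[C@H](Oc3nccc(C#N)c3C)CC[C@H]2C)c(-n2nccn2)n1` gives 21 nM in a functional assay on cells for antagonist activity at Orexin receptor type 2 (Homo sapiens), read by FLIPR and calcium flux (on this read-out higher numbers stand for weaker inhibition and lower numbers for stronger inhibition), the higher of the two numbers in hand; compound 2 `Cc1c(C#N)ccnc1O[C@@H]1CC[C@@H](C)N(C(=O)c2ccccc2-n2ncnn2)C1` gives 7.7 nM in this assay. Compound 3 `COc1ccc(C(=O)N2C[C@H](Oc3nccc(C#N)c3C)CC[C@H]2C)c(SC)n1` carries methylsulfanyl in place of 2H-1,2,3-triazol-2-yl on an aromatic carbon. Among the compounds with values here, no measured pair isolates such a change, so the expected size of the step rests only on the numbers for compound 1 and the change itself. The step from compound 1 to compound 3 is estimated at a 2.9-fold higher number from compound 1 to compound 3 (0.46 log units; beyond the scatter), toward weaker inhibition. Compound 3 is therefore expected to give about 60 nM, within a range of 15 nM to 250 nM in this assay.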

Compound 3, half-maximal inhibitory concentration: 22 nM
Compound 3: the middle estimate sits 2.7-fold (0.44 log units) above what was measured, within the range that was stated.
By their numbers in this assay, from the lowest: compound 2; then compounds 1 and 3 (each within the scatter of the next).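

Placing methylsulfanyl in place of 2H-1,2,3-triazol-2-yl on this aromatic carbon, next to the ring nitrogen, gives a 1.0-fold higher number from compound 1 to compound 3 (0.02 log units; within the scatter) in this assay. At this place, then, the five-membered aromatic ring is not required to hold the read-out: a group with no ring and fewer heavy atoms serves within the scatter. Nothing available explains why the two groups match.

Going by these compounds, it remains open whether the sulfur atom matters here, and how an ethylsulfanyl chain or a dimethylamino group on the same carbon would compare.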